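Inverting One Stereocentre of Compound 3

This account rests on a few compounds, and the source may have more. Where it says the series, first, only, none or still open, it means among the compounds named here.

Among the compounds with values here, in a functional assay on HBL-100 cells (Homo sapiens) for antiproliferative activity, read by luminescence and CellTiter-Glo, with a stated time of 48 h (on this read-out higher numbers stand for weaker inhibition and lower numbers for stronger inhibition), compound 3 `O=C1C=CC[C@H](/C=C/c2ccc(F)cc2)O1` gives 14100 nM, the only true number so far. Compound 1 `COc1ccc(/C=C/[C@@H]2CC=CC(=O)O2)cc1` reads > 100000 nM, which is a limit of the assay and not a number. Compound 2 `O=C1C=CC[C@@H](/C=C/c2ccc([N+](=O)[O-])cc2)O1` reads > 100000 nM, which is also a limit.

Compound 4 `O=C1C=CC[C@@H](/C=C/c2ccc(F)cc2)O1` departs from compound 3 in one way: the two compounds have the same atoms and bonds and differ only in configuration as drawn: 1 of 2 stereo elements differ; a stereocentre at a saturated ring carbon is drawn R in compound 3 and S in compound 4. Within the data shown here, the only measured step, a step that the two limits leave unreadable from compound 1 to compound 2, swaps nitro for methoxy on an aromatic carbon and inverts no stereocentre, so it gives no size to borrow. Compound 1 and compound 2 share the configuration drawn in compound 4 but differ from it on the aromatic ring, so the limit of > 100000 nM in this assay, at which 2 of the 3 values shown sit, offers only a weak hint toward weaker inhibition. A modest shift in that direction is therefore expected in this assay, with an estimated size of a 1.8-fold higher number from compound 3 to compound 4 (0.25 log units; within the scatter). For compound 4 the expected value is 25000 nM, with an estimated range from 7000 nM to 100000 nM.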

Compound 4, half-maximal inhibitory concentration: > 100000 nM
Compound 4 ended at the assay's limit (the forecaster's own chance of this, stated with the estimate: 20%); at least 4.0-fold (0.60 log units) between middle value and limit.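

Inverting the stereocentre at the saturated ring carbon from R to S gives an at least 7.0-fold higher number from compound 3 to compound 4 (0.85 log units; beyond the scatter) in this assay, the first step in this series with a readable size, so this position clearly matters for antiproliferative activity. The shift can be tied to that stereocentre alone because nothing else separates the pair: the fact that compounds 3 and 4 differ only in the configuration as drawn. Compound 4 gives > 100000 nM, which is a limit of the assay and not a number, so the step has a lower bound but no known upper size.

On these data alone, the steps among compounds 1, 2 and 4 cannot be read, since all three sit at the limit, so the effect of the aromatic group in this configuration stays open. As far as these compounds go, whether a chloro group or an amine in place of fluoro, in the configuration of compound 3, would give a lower number also remains open.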